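This account rests on a few compounds, and the source may have more. Where it says the series, first, only, none or still open, it means among the compounds named here.

Values so far in a functional assay on PC-3 cells (Homo sapiens) for inhibition, read by MTT assay; a higher number here means a weaker inhibitor, a lower number a stronger inhibitor:

- compound 1 `Cc1ccc(-c2nnc(NC(=O)CCCCCCC(=O)NO)s2)o1` gives 880 nM
- compound 2 `O=C(CCCCCCC(=O)Nc1nnc(-c2cccs2)s1)NO` gives 880 nM
- compound 3 `O=C(CCC(=O)Nc1nnc(-c2ccc(Cl)cc2)s1)NO` gives 14700 nM

Compound 3 has the highest number of the three, with 14700 nM as its value, and so is the weakest inhibitor measured so far. Compound 1 and compound 2 both lie well below it, beyond the scatter, and compound 3 differs from them in more than one place.

Compound 4 `O=C(CCC(=O)Nc1nnc(-c2ccc(O)cc2)s1)NO` differs from compound 3 in one place only, on an aromatic carbon of a six-membered aromatic ring of carbon only, para to a large group. The change is hydroxy in place of chloro on an aromatic carbon and reads as 4-chlorophenyl to 4-hydroxyphenyl.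

Going by the values given here, only one measured step is at hand, no change at the digits printed from compound 1 to compound 2 (within the scatter) and it lies within the scatter. It concerns other groups, so it bears on this change only loosely. Among the compounds with values here, no measured pair covers chloro and hydroxy, and nothing measured gives a direction in this assay for this swap. The estimated step is a 1.2-fold lower number from compound 3 to compound 4 (0.09 log units; within the scatter) and it is expected to stay within the scatter, with wide margins on both sides. Compound 4 is expected at 12000 nM within a range from 4000 nM to 40000 nM as estimated here.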

Compound 4, half-maximal inhibitory concentration: 14700 nM
The estimate for compound 4 lay 1.2-fold (0.09 log units) below the measured number, within the range that was stated.
By their numbers in this assay, from the lowest: compounds 1 and 2 (each within the scatter of the next); then compounds 3 and 4 (each within the scatter of the next).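

In this assay the series now has its first measured swap at this position, 4-chlorophenyl to 4-hydroxyphenyl, and it gives no change at the digits printed from compound 3 to compound 4 (within the scatter). The earlier step concerned only 5-methylfuran-2-yl and thiophen-2-yl, so it said nothing about a group on the six-membered aromatic ring; here a hydrogen-bond donor and a hydrogen-bond acceptor enter where chloro had neither, and the number stays within the scatter. For this pair, chloro and hydroxy are not told apart by this read-out, though one swap on one chain sets no rule for the position. No measured property is available to account for this outcome.

As far as these compounds go, whether an amine or a carboxylic acid at the same place would read like chloro and hydroxy stays open. Going by these compounds alone, also open is whether this swap would read alike on a longer chain such as the one in compound 1 and compound 2, which differ from compound 3 and compound 4 in more than one place and so give no direct comparison.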